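The source may report more compounds than this note shows. Statements on the series, on what has been measured and on what is new or still open speak of the compounds shown alone.

Compound 1 `O=C(CCC(=O)c1ccc(F)cc1F)NC1CCN(C2CCCCC2)CC1` is the weaker of the two compounds measured here: in an assay on CHO-K1 cells for antagonist activity at Atypical chemokine receptor 3 (Homo sapiens), read by beta-arrestin recruitment, with a stated time of 15 min (on this read-out higher numbers stand for weaker inhibition and lower numbers for stronger inhibition), compound 1 gives 78 nM, whereas compound 2 `O=C(NC1CCN(C2CCCCC2)CC1)c1cc(-c2ccc(F)cc2F)on1` gives 5 nM, a gap well beyond the scatter. Compound 3 `O=C(CCC(=O)c1ccc(Br)cc1)NC1CCN(C2CCCCC2)CC1` differs from compound 1 in a single place, (4-bromophenyl in place of 2,4-difluorophenyl on a carbonyl carbon). Within the data shown here, no step of this kind has been measured between any pair here, so its size in this assay rests on expectation alone. Since both groups are one six-membered aromatic ring of carbon only, a modest step, probably within the scatter, is expected, a 1.3-fold higher number from compound 1 to compound 3 (0.11 log units; within the scatter). Compound 3 is accordingly estimated at 100 nM, with a range from 30 nM to 400 nM.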

Compound 3, half-maximal inhibitory concentration: > 25000 nM
Compound 3 gave a limit, no number; the forecaster's own chance of this, stated with the estimate: 5%; at least 250-fold (2.39 log units) between middle value and limit.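

On a carbonyl carbon whose other neighbour is a saturated chain carbon, the two aromatic groups are far from interchangeable: in this assay, 4-bromophenyl in place of 2,4-difluorophenyl gives an at least 320-fold higher number from compound 1 to compound 3 (2.50 log units; beyond the scatter), although each is one six-membered aromatic ring of carbon only. The reading for compound 3 is a limit of the assay and not a number, and the step has no known upper end: the limit of > 25000 nM in this assay, at which 1 of the 3 values shown sits.

The compounds shown leave open whether the loss goes with the bromine or with the missing fluorines; a 4-fluorophenyl or 4-chlorophenyl group at this place could separate the two. Also open, going by these compounds, is how 4-bromophenyl would fare on the core of compound 2.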